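The compounds below may be only part of what the source reports. "The series", "measured", "known", "first", "only" and "open" are said of these compounds alone.

Compound 2 `Cc1c(C)c2ccc(OC3CCN(Cc4cccc(Cl)c4)CC3)cc2oc1=O` gives 285 nM in an assay for inhibition of Amine oxidase [flavin-containing] B (Homo sapiens), read by fluorescence, using microsomes, with stated times of 20 min and 30 min; on this read-out higher numbers stand for weaker inhibition and lower numbers for stronger inhibition. For the measured compounds named here, the only other measured compound, compound 1 `Cc1c(C)c2ccc(OC3CCN(C)CC3)cc2oc1=O`, gives 274 nM in this assay, and the step of a 1.0-fold higher number from compound 1 to compound 2 (0.02 log units; within the scatter) lies within the scatter, so the two cannot be told apart. Compound 3 `Cc1c(C)c2ccc(OC3CCN(Cc4ccc(Cl)cc4)CC3)cc2oc1=O` differs from compound 2 by 4-chlorophenyl in place of 3-chlorophenyl on a saturated chain carbon bound to an amine nitrogen in a ring. Going by the values given here, no measured step moves the chlorine around that ring; the one comparison available, a 1.0-fold higher number from compound 1 to compound 2 (0.02 log units; within the scatter), concerns adding the whole group and was itself within the scatter. A step of no change at the digits printed from compound 2 to compound 3 (within the scatter) is therefore expected, meaning none beyond the scatter. Compound 3 is estimated at 285 nM, with a range from 100 nM to 800 nM.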

Compound 3, half-maximal inhibitory concentration: 876 nM
For compound 3 the middle estimate is 3.1-fold (0.49 log units) below the measured one; the whole stated range lies below it.
By their numbers in this assay, from the lowest: compounds 1 and 2 (each within the scatter of the next); then compound 3.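

In this assay the place of the chlorine counts: moving from 3-chlorophenyl to 4-chlorophenyl, with the same atoms, gives a 3.1-fold higher number from compound 2 to compound 3 (0.49 log units; beyond the scatter) and so means weaker inhibition. Adding a chlorophenyl at this place is therefore not always without effect: 4-chlorophenyl in place of hydrogen gives a 3.2-fold higher number from compound 1 to compound 3 (0.50 log units; beyond the scatter) while the same step with 3-chlorophenyl stayed within the scatter. No evidence at hand accounts for this difference.

Going by these compounds, it remains open whether a phenyl without chlorine or a 4-methoxyphenyl at this place would match compound 2 or compound 3. Also open, on these data alone, is what a longer chain between the phenyl and the amine nitrogen would do.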